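This account rests on a few compounds, and the source may have more. Where it says the series, first, only, none or still open, it means among the compounds named here.

Measured so far:
compound 1 `O=C(O)CC(NC(=O)c1c(Cl)cccc1Cl)c1ccccc1`: > 100000 nM (a limit)
compound 2 `COc1ccc(C(=O)NC(CC(=O)O)c2ccc(C(C)(C)C)cc2)cc1`: > 100000 nM (a limit)
compound 3 `CC(C)(C)c1ccc(C(CC(=O)O)NS(=O)(=O)c2ccc(C(F)(F)F)cc2)cc1`: 53700 nM

All three compounds were tested in a functional assay on MDA-MB-231 cells (Homo sapiens) for antiproliferative activity, read by MTT assay, with a stated time of 24 h; on this read-out lower numbers stand for stronger inhibition and higher numbers for weaker inhibition. In this assay compound 1 gives > 100000 nM, which is a limit and not a number. Compound 2 gives > 100000 nM, which is also a limit. Going by these compounds, compound 1 therefore stands at the limit of > 100000 nM in this assay, at which 2 of the 3 values shown sit, so its true value is unknown. Only compound 3 gives an actual number, 53700 nM.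

The next compound, compound 4 `O=C(O)CC(NC(=O)c1c(Cl)cccc1Cl)c1ccc(Cl)cc1Cl`, keeps the rest of compound 1 and changes one group: 2,4-dichlorophenyl in place of phenyl on a saturated chain carbon bound to an amide-type nitrogen and a saturated chain carbon. In words, 2,4-dichlorophenyl takes the place of phenyl on a saturated chain carbon bound to an amide-type nitrogen and a saturated chain carbon.

Going by the values given here, no measured pair of compounds shows what a change of this kind does, so any expectation is loose. A modest step towards stronger inhibition is expected, although compound 4 may again reach only the limit. Among the compounds with values here, the one real number, compound 3 at 53700 nM, suggests that a measurable value would lie in the same broad region. The expected change is an at least 1.4-fold lower number from compound 1 to compound 4 (0.15 log units; that floor lies within the scatter). The estimate for compound 4 is 70000 nM, with an expected range from 20000 nM to 150000 nM.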

Compound 4, half-maximal inhibitory concentration: > 100000 nM
Compound 4: a limit, no number (the forecaster's own chance of this, stated with the estimate: 50%); middle value at least 1.4-fold (0.15 log units) from the limit.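

In this assay compound 4 gives > 100000 nM as a limit and not a number. Compound 1 also stands at a limit, so the step between compound 1 and compound 4 cannot be read. Still open is whether 2,4-dichlorophenyl in place of phenyl changes inhibition at all, as most values sit at one limit: the limit of > 100000 nM in this assay, at which 3 of the 4 values shown sit.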